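Swapping ring substituents on the pyridine of a TRPV1 antagonist

A few compounds are considered here, and "the series" means these few. Any claim that something is new, unique, unknown or untested is made for them only; others in the source may bear on it.

Compound 2 `CC(C(=O)NCc1ccc(C(F)(F)F)nc1C1CCC(C)(C)CC1)c1ccc(NS(C)(=O)=O)c(F)c1`: 0.4 nM
Compound 1 `CC(C(=O)NCc1ccc(C(F)(F)F)nc1Cl)c1ccc(NS(C)(=O)=O)c(F)c1`: 0.2 nM

In an assay on CHO cells for antagonist activity at transient receptor potential cation channel subfamily V member 1 (Homo sapiens), read by FLIPR and calcium flux (a lower number here means a stronger inhibitor, a higher number a weaker inhibitor), compound 2 gives 0.4 nM; in this assay compound 1 gives 0.2 nM. Among the compounds with values here, the only measured step, a 2.0-fold higher number from compound 1 to compound 2 (0.30 log units; within the scatter), shows that these two numbers lie within the scatter of each other. Compound 3 `CC(C(=O)NCc1ccc(C(F)(F)F)nc1C1CCC(F)(F)CC1)c1ccc(NS(C)(=O)=O)c(F)c1` differs from compound 2 by 4,4-difluorocyclohexyl in place of 4,4-dimethylcyclohexyl on an aromatic carbon. Within the data shown here, no measured step bears on this exchange directly; the one step at this position was within the scatter. A step of similar size, or none beyond the scatter, is therefore expected from compound 2 to compound 3, namely a 1.3-fold higher number from compound 2 to compound 3 (0.10 log units; within the scatter). Compound 3 is estimated at 0.5 nM, within 0.2 nM to 1.5 nM.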

Compound 3, inhibition constant: 1.5 nM
Compound 3: middle estimate off by 3.0-fold (0.48 log units), on the low side; measured number inside the range.
By their numbers in this assay, from the lowest: compounds 1 and 2 (each within the scatter of the next); then compound 3.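

In this assay, within the data shown here, the position next to the ring nitrogen responds to what the cyclohexyl ring carries: 4,4-difluorocyclohexyl in place of 4,4-dimethylcyclohexyl gives a 3.8-fold higher number from compound 2 to compound 3 (0.57 log units; beyond the scatter) and is the first step here beyond the scatter. Replacing chloro with the same group gives a 7.5-fold higher number from compound 1 to compound 3 (0.88 log units; beyond the scatter) while 4,4-dimethylcyclohexyl stayed within the scatter of chloro, so among these compounds a cyclohexyl ring at this position does not alone set the number. Nothing available accounts for this difference between the two rings. On these data alone, whether an unsubstituted cyclohexyl, a morpholine or a tert-butyl group would fall with compound 2 or with compound 3 remains open.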